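A few compounds are considered here, and "the series" means these few. Any claim that something is new, unique, unknown or untested is made for them only; others in the source may bear on it.

Compound 1 `CS(=O)(=O)Nc1ccc([N+](=O)[O-])cc1OCc1ccc([N+](=O)[O-])cc1` gives 400 nM in an assay on SK-BR-3 cells for inhibition of Aromatase (Homo sapiens); on this read-out lower numbers stand for stronger inhibition and higher numbers for weaker inhibition. Compound 2 `COc1ccc(COc2cc([N+](=O)[O-])ccc2N(C)S(C)(=O)=O)cc1` gives 470 nM in this assay, and compound 3 `CS(=O)(=O)Nc1ccc([N+](=O)[O-])cc1OCc1ccc(F)cc1` gives 580 nM; both numbers sit within the scatter of compound 1, so no order among the three is claimed. Going by the values given here, the only one-place step among them, a 1.5-fold higher number from compound 1 to compound 3 (0.16 log units; within the scatter), is within the scatter. Compound 4 `CS(=O)(=O)Nc1ccc([N+](=O)[O-])cc1OCc1ccc(-c2ccccc2)cc1` differs from compound 1 by phenyl in place of nitro on an aromatic carbon. Among the compounds with values here, only the step from compound 1 to compound 3 bears on this exchange at the same position, and it was within the scatter; no measured step brings in a phenyl, so the range is kept wide. For compound 4 the estimate in this assay is 500 nM, between 150 nM and 1800 nM, which means an expected step of a 1.3-fold higher number from compound 1 to compound 4 (0.10 log units; within the scatter).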

Compound 4, half-maximal inhibitory concentration: 850 nM
Estimate against measurement, compound 4: 1.7-fold (0.23 log units) below; low and high end bracket the measured number.
By their numbers in this assay, from the lowest: compounds 1, 2, 3 and 4 (each within the scatter of the next, the first and the last beyond it).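

Nitro to phenyl on this aromatic carbon, para to a large group, gives the only step here beyond the scatter, a 2.1-fold higher number from compound 1 to compound 4 (0.33 log units; beyond the scatter) and modest in size. Phenyl and fluoro are not separated in this assay by the step of a 1.5-fold higher number from compound 3 to compound 4 (0.17 log units; within the scatter) and so the position has not yet shown a clear order between these two groups. No measurement on hand offers an explanation for the rise from compound 1 to compound 4. Open, from the compounds shown here alone, is how an amine, a carboxylic acid or a longer chain at this carbon would read, and whether a second aromatic ring on the phenyl would extend the step.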